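This account rests on a few compounds, and the source may have more. Where it says the series, first, only, none or still open, it means among the compounds named here.

In an ADME assay on NIH3T3 cells (Mus musculus) for cytotoxicity, read by MTT assay, with a stated time of 24 h (on this read-out higher numbers stand for weaker inhibition and lower numbers for stronger inhibition), the measured members of the series are:
compound 1, `O=C(CSc1ncccn1)N/N=c1/scc(-c2ccc([N+](=O)[O-])cc2)n1-c1ccccc1`: 193 ug/mL
compound 2, `O=C(CSc1ncccn1)N/N=c1/scc(-c2ccccc2)n1-c1ccccc1`: 107 ug/mL
compound 3, `O=C(CSc1ncccn1)N/N=c1/scc(-c2ccc(Br)cc2)n1-c1ccccc1`: 273 ug/mL

Compound 3 stands at the high end of the three numbers, though its gap to compound 1 is within the scatter (a 1.4-fold higher number from compound 1 to compound 3 (0.15 log units; within the scatter)); only against compound 2 is there a modest difference beyond the scatter (a 2.6-fold higher number from compound 2 to compound 3 (0.41 log units; beyond the scatter)). Between compound 1 and compound 2 the step is a 1.8-fold lower number from compound 1 to compound 2 (0.26 log units; within the scatter). Among the measured compounds shown here, all three compounds therefore sit in a narrow band, and the only change that moved the number beyond the scatter was bromo in place of hydrogen.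

Compound 4, `COc1ccc(-c2cs/c(=N/NC(=O)CSc3ncccn3)n2-c2ccccc2)cc1`, differs from compound 3 in one place: methoxy in place of bromo on an aromatic carbon. For the measured compounds named here, no measured step introduces a methoxy, so the change has no direct precedent. What bears on it is the behaviour of that aromatic carbon across the three steps above: nitro, hydrogen and bromo shift the number only modestly at most. The expected step is therefore a 1.2-fold lower number from compound 3 to compound 4 (0.09 log units; within the scatter), most likely nothing beyond the scatter, with some allowance for a lower number since compound 2 sits lower. Compound 4 is expected to give 220 ug/mL in this assay, within a range from 110 ug/mL to 440 ug/mL.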

Compound 4, half-maximal inhibitory concentration: 450 ug/mL
Compound 4: the middle estimate sits 2.0-fold (0.31 log units) below what was measured; measured number outside the range, above it.
By their numbers in this assay, from the lowest: compounds 2, 1, 3 and 4 (each within the scatter of the next, the first and the last beyond it).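

Working notes on the aromatic carbon para to a large group, in this assay: methoxy is the first group here to stand beyond the scatter against both hydrogen (a 4.2-fold higher number from compound 2 to compound 4 (0.62 log units; beyond the scatter)) and nitro (a 2.3-fold higher number from compound 1 to compound 4 (0.37 log units; beyond the scatter)), whereas bromo does so only against hydrogen. Methoxy and bromo remain within the scatter of each other (a 1.6-fold higher number from compound 3 to compound 4 (0.22 log units; within the scatter)), so the series now shows two groups separated from hydrogen at this carbon, with nitro in compound 1 going against any general rule that a group here moves the number away from hydrogen. Nothing available accounts for these steps, and no reason for them can be offered.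

As far as these compounds go, how the number responds to an amine, a carboxylic acid or a longer chain such as ethoxy on this same aromatic carbon remains open. All four compounds vary at this carbon alone, leaving the response to changes elsewhere on the shared core unknown.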